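The source may report more compounds than this note shows. Statements on the series, on what has been measured and on what is new or still open speak of the compounds shown alone.

Working notes on the series, step from compound 2 to compound 4.

Three compounds sharing one core have numbers in a functional assay on the whole organism (strain albino) for inhibition, with Rattus norvegicus as the target, read by paw edema, with stated times of 1 h and 3 h, at a dose of 20 mmol/kg by the intraperitoneal route; a higher number here means a stronger effect of the compound at the dose given, a lower number a weaker effect. Compound 1 `N#CC1=C(NCC(=O)O)N(c2ccccc2)C(=O)N2CCCCC(N3CCCC3)C12` gives 89.2%. Compound 3 `N#CC1=C(NC(=O)c2ccccc2O)N(c2ccccc2)C(=O)N2CCCCC(N3CCCC3)C12` gives 65.4%. Compound 2 `COc1ccc(N/C=N/C2=C(C#N)C3C(N4CCCC4)CCCCN3C(=O)N2c2ccccc2)cc1` gives 50.2%, the lowest of the three: the gap to compound 3 is a number 15.2 percentage points higher from compound 2 to compound 3 (beyond the scatter), and the step of a number 39 percentage points lower from compound 1 to compound 2 (beyond the scatter) is the largest movement in the set. The change a number 23.8 percentage points lower from compound 1 to compound 3 (beyond the scatter) places compound 3 between the other two.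

Compound 4 `N#CC1=C(NCC(=O)N2CCCCC2)N(c2ccccc2)C(=O)N2CCCCC(N3CCCC3)C12` is not yet measured. Relative to compound 2 the change is a group of 10 heavy atoms (7 carbon, 2 nitrogen, 1 oxygen; one six-membered non-aromatic ring with 1 hetero atom) in place of a group of 11 heavy atoms (8 carbon, 2 nitrogen, 1 oxygen; one six-membered aromatic ring of carbon only), on a double-bonded ring carbon.

Within the data shown here, two measured steps bear on this. Both replacements of the group that leaves compound 2 ended higher: compound 3 at 65.4% and compound 1 at 89.2%. The entering group in compound 4 is of the same size class as the group that enters in the step of a number 15.2 percentage points higher from compound 2 to compound 3 (beyond the scatter), which was modest. Among the measured compounds shown here, no measured step leads to an amide of this kind, so the size is uncertain, but the direction is expected upward. The step thus estimated, a number 19.8 percentage points higher from compound 2 to compound 4 (beyond the scatter), would be modest, beyond the scatter. Compound 4 is therefore expected to give 70% in this assay, with a plausible range from 52% to 88%.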

Compound 4, a percentage reported as inhibition, in the whole organism at one dose (the size of the read-out at that dose, not a potency): 53.5%
The estimate for compound 4 lay 16.5 percentage points above the measured number, and the stated range covers the measured number.
By their numbers in this assay, from the lowest: compounds 2 and 4 (each within the scatter of the next); then compound 3; then compound 1.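

In this assay, the entering ((piperidin-1-yl)carbonyl)methyl-bearing amino group gives a number 3.3 percentage points higher from compound 2 to compound 4 (within the scatter), so compound 4 goes against the rise seen with both earlier replacements of the group in compound 2, and a change at this double-bonded ring carbon need not move the number. Among these compounds, the sharper reading comes from the single change on the carbonyl carbon, piperidin-1-yl in place of hydroxy, which gives a number 35.7 percentage points lower from compound 1 to compound 4 (beyond the scatter): the amine nitrogen bearing a methylene and a carbonyl does not by itself keep the number of compound 1, and what stands on that carbonyl carbon matters. On the amine nitrogen, ((piperidin-1-yl)carbonyl)methyl in place of (2-hydroxyphenyl)carbonyl gives a number 11.9 percentage points lower from compound 3 to compound 4 (beyond the scatter), and no measurement at hand offers an explanation for any of these steps.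

The compounds shown leave open whether the higher number of compound 1 is specific to the carboxylic acid, since a methyl ester, a primary amide or a dimethylamino group on the same carbonyl carbon would separate the hydroxy group from the piperidine ring. They also leave open how a longer chain between the amine nitrogen and the carboxylic acid would read.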